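Replacing furan-3-yl with phenyl on the shared core

A few compounds are considered here, and "the series" means these few. Any claim that something is new, unique, unknown or untested is made for them only; others in the source may bear on it.

Compound 1 `O=c1[nH]cnc2c1c(-c1ccccc1)cn2[C@@H]1O[C@H](CO)[C@@H](O)[C@H]1O`: > 100000 nM (a limit)
Compound 2 `Nc1nc2c(c(-c3ccoc3)cn2[C@@H]2O[C@H](CO)[C@@H](O)[C@H]2O)c(=O)[nH]1`: 21500 nM

Both compounds were tested in an ADME assay on BJ cells (Homo sapiens), read by MTT assay, with a stated time of 72 h; on this read-out lower numbers stand for stronger inhibition and higher numbers for weaker inhibition. Compound 1 reached only a limit, > 100000 nM, and not a number. Going by the values given here, compound 2 therefore holds the only true number so far, 21500 nM, so it has no measured neighbour for comparison.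

Compound 3 `Nc1nc2c(c(-c3ccccc3)cn2[C@@H]2O[C@H](CO)[C@@H](O)[C@H]2O)c(=O)[nH]1` has phenyl in place of furan-3-yl on an aromatic carbon. Among the compounds with values here, no measured step shows what such a change does in this assay, so the expectation rests on compound 2 at 21500 nM. A small move toward weaker inhibition is expected, possibly no larger than the usual scatter, and the assay may report only a limit. The estimate amounts to an expected step of a 1.9-fold higher number from compound 2 to compound 3 (0.27 log units; within the scatter). Compound 3 is estimated at 40000 nM, with an expected range from 12000 nM to 100000 nM.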

Compound 3, half-maximal inhibitory concentration: > 100000 nM
Compound 3: a limit, no number; the forecaster's own chance of this, stated with the estimate: 35%; middle value at least 2.5-fold (0.39 log units) from the limit.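

In this assay, phenyl in place of furan-3-yl on this aromatic carbon gives an at least 4.6-fold higher number from compound 2 to compound 3 (0.66 log units; beyond the scatter), the first readable step among these compounds. Going by these compounds alone, it shows that changing this one group, two ring bonds from the ring nitrogen, can move the read-out beyond the usual scatter, and that furan-3-yl gives the only true number so far. Going by these compounds, the full size of the step stays unknown, and the step for amino in place of hydrogen cannot be read, as its two ends are both limits: the limit of > 100000 nM in this assay, at which 2 of the 3 values shown sit.

The compounds shown do not separate the effect of ring size from that of the ring oxygen. They also leave open where thiophen-3-yl, pyridin-3-yl or a carboxylic acid on this aromatic carbon would fall.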